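The compounds below may be only part of what the source reports. "The series", "measured", "known", "first", "only" and "open" are said of these compounds alone.

Three compounds share one core and differ only in the group carried on an amide-type nitrogen. Compound 1 `CCN(C(=O)OC)c1c(N)nc(-c2nn(Cc3ccccc3F)c3ncccc23)nc1N` gives 0.2 uM in an assay on cells for activation of Guanylate cyclase soluble subunit alpha-1 (Rattus norvegicus), read by cGMP accumulation and immunoassay, with a stated time of 10 min; on this read-out lower numbers stand for an effect already at smaller amounts and higher numbers for an effect only at larger amounts of compound. Compound 2 `COC(=O)N(CCO)c1c(N)nc(-c2nn(Cc3ccccc3F)c3ncccc23)nc1N` gives 0.3 uM in this assay, and the step of a 1.5-fold higher number from compound 1 to compound 2 (0.18 log units; within the scatter) stays within the scatter. Compound 3 `COC(=O)N(Cc1cccc(F)c1)c1c(N)nc(-c2nn(Cc3ccccc3F)c3ncccc23)nc1N` gives 0.2 uM in this assay, level with compound 1 and with it the lowest of the three numbers, though the steps of no change at the digits printed from compound 1 to compound 3 (within the scatter) and a 1.5-fold lower number from compound 2 to compound 3 (0.18 log units; within the scatter) both lie within the scatter. Compound 4 `COC(=O)N(Cc1ccc(F)cc1)c1c(N)nc(-c2nn(Cc3ccccc3F)c3ncccc23)nc1N` has the same atoms as compound 3, joined differently: 4-fluorophenyl in place of 3-fluorophenyl on a saturated chain carbon bound to an amide-type nitrogen. Among the measured compounds shown here, no measured step bears directly on shifting a fluorine within the ring on this carbon, but every change made at this place so far, whether hydroxy for hydrogen or 3-fluorophenyl for methyl or for hydroxymethyl, stayed within the scatter. The step of no change at the digits printed from compound 3 to compound 4 (within the scatter) is therefore expected to stay within the scatter as well. Compound 4 is estimated to give 0.2 uM in this assay, within a range from 0.1 uM to 0.5 uM.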

Compound 4, minimum effective concentration: 0.7 uM
Estimate against measurement, compound 4: 3.5-fold (0.54 log units) below; measured number above the stated range.
By their numbers in this assay, from the lowest: compounds 1, 3 and 2 (each within the scatter of the next); then compound 4.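

Moving the fluorine from the 3-fluorobenzyl to the 4-fluorobenzyl arrangement gives a 3.5-fold higher number from compound 3 to compound 4 (0.54 log units; beyond the scatter) in this assay, the first step at this place to leave the scatter, although the two groups have the same atoms. Among the compounds shown here, compound 4 also stands apart from the ethyl and hydroxyethyl compounds, with a 3.5-fold higher number from compound 1 to compound 4 (0.54 log units; beyond the scatter) and with a 2.3-fold higher number from compound 2 to compound 4 (0.37 log units; beyond the scatter) as well, so this place does respond to where the fluorine sits on the ring, even though swapping ethyl, hydroxyethyl and 3-fluorobenzyl among themselves showed no such step. Nothing measured here gives a reason for this shift.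

From the compounds shown here alone, whether a plain benzyl group or a 4-chlorobenzyl group would fall with compound 3 or with compound 4 stays open. Also open, going by these compounds, is how a carboxylic acid or an amine carried on this chain would compare.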